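One added chloro on a phenyl group

The source may hold more compounds than are shown below. What is called first, only, known or untested is meant among the compounds shown, and "the series" means these compounds.

Of the compounds shown here, three sharing one core have been measured in a physicochemical assay for solubility, at pH 7.4; on this read-out lower numbers stand for lower solubility and higher numbers for higher solubility. Compound 1 `O=C(N[C@H]1CN(S(=O)(=O)c2ccccc2)C[C@@H]1C(=O)N[C@H]1CCCNC1)c1cn(C2CC2)cn1` gives 664000 nM, compound 2 `O=C(N[C@H]1CN(S(=O)(=O)c2ccccc2)C[C@@H]1C(=O)N[C@H]1CCCNC1)c1cc(-c2ccccc2)on1` gives 94000 nM, and compound 3 `Cc1oc(-c2ccc(C(F)(F)F)cc2)nc1C(=O)N[C@H]1CN(S(=O)(=O)c2ccccc2)C[C@@H]1C(=O)N[C@H]1CCCNC1` gives 13000 nM. Compound 2 therefore holds the middle place of the three numbers, clearly apart from both of the others.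

Compound 4 `O=C(N[C@H]1CN(S(=O)(=O)c2ccccc2)C[C@@H]1C(=O)N[C@H]1CCCNC1)c1cc(-c2ccccc2Cl)on1` has not yet been measured in this assay. It differs from compound 2 in one place, where phenyl becomes 2-chlorophenyl: chloro in place of hydrogen on an aromatic carbon.

Among the compounds with values here, no measured pair shows this exact change, so the evidence is indirect. Within the data shown here, the only measured step is a 7.1-fold lower number from compound 1 to compound 2 (0.85 log units; beyond the scatter), a modest one in which 5-phenyl-1,2-oxazol-3-yl replaces 1-cyclopropyl-1H-imidazol-4-yl on a carbonyl carbon. That swaps a whole group, whereas the edit here is far smaller, so a smaller step seems likely. Compound 3, which carries a substituted phenyl group, shows the lowest number at 13000 nM, but it differs from compound 2 in more than one place. This hints only weakly at a downward direction.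

The expected change is a 1.6-fold lower number from compound 2 to compound 4 (0.19 log units; within the scatter), a slightly lower number that may not clear the scatter. For compound 4 the estimated value is 60000 nM, with an expected range of 22000 nM to 130000 nM.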

Compound 4, solubility: 12000 nM
Compound 4: the middle estimate sits 5.0-fold (0.70 log units) above what was measured, outside the stated range (below it).
By their numbers in this assay, from the lowest: compounds 4 and 3 (each within the scatter of the next); then compound 2; then compound 1.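

In this assay, the smallest possible edit on the phenyl group, chloro in place of hydrogen on an aromatic carbon ortho to a large group, gives a 7.8-fold lower number from compound 2 to compound 4 (0.89 log units; beyond the scatter) and so shows that this place on the ring is far from silent. Until now a drop of this size had been seen only when a whole group was exchanged, as in a 7.1-fold lower number from compound 1 to compound 2 (0.85 log units; beyond the scatter), yet here one added heavy atom is enough, and the full exchange that includes the chloro amounts to a 55-fold lower number from compound 1 to compound 4 (1.74 log units; beyond the scatter) and is the largest step seen so far. Within the data shown here, no measurement on hand explains why a single chloro at this place moves the number so far.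

The compounds shown leave open whether the drop belongs to chloro itself or would come with any group at this place, and a fluoro, a methyl, a methoxy or an amine there would separate those two readings. They also leave open whether the position on the phenyl group matters, which 3-chlorophenyl or 4-chlorophenyl in place of 2-chlorophenyl would answer.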